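A few compounds are considered here, and "the series" means these few. Any claim that something is new, unique, unknown or untested is made for them only; others in the source may bear on it.

- Compound 1 `Cn1ncc(Cl)c1-c1cc(C(=O)N[C@@H]2CN[C@H](CCN3CCCCC3)C[C@H]2c2ccc(Cl)c(Cl)c2)oc1Cl` gives 1020 nM
- Compound 2 `Cn1ncc(Cl)c1-c1cc(C(=O)N[C@@H]2CN[C@H](CC(=O)NCC(O)CO)C[C@H]2c2ccc(Cl)c(Cl)c2)oc1Cl` gives 7090 nM

In a functional assay on HCT-116 cells (Homo sapiens) for antiproliferative activity, read by sulforhodamine B assay, with a stated time of 72 h (a lower number here means a stronger inhibitor, a higher number a weaker inhibitor), compound 2 (7090 nM) has the higher number of the pair, making it the weaker inhibitor. Compound 3 `Cn1ncc(Cl)c1-c1cc(C(=O)N[C@@H]2CN[C@H](CCO)C[C@H]2c2ccc(Cl)c(Cl)c2)oc1Cl` differs from it by hydroxymethyl in place of (2,3-dihydroxypropyl)carbamoyl on a saturated chain carbon bound to a saturated ring carbon and, in words, carries hydroxymethyl in place of (2,3-dihydroxypropyl)carbamoyl on a saturated chain carbon bound to a saturated ring carbon. Going by the values given here, one measured step touches this same place: a 7.0-fold higher number from compound 1 to compound 2 (0.84 log units; beyond the scatter) and it is modest. Losing the group of compound 2 should therefore give back part of that step, a modest move to a lower number in this assay, though a single step is thin evidence. The expected change is a 2.0-fold lower number from compound 2 to compound 3 (0.31 log units; beyond the scatter) as an estimate. Compound 3 is estimated at 3500 nM (expected range 1200 nM to 10000 nM).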

Compound 3, half-maximal inhibitory concentration: 340 nM
For compound 3 the middle estimate is 10-fold (1.01 log units) above the measured one; the whole stated range lies above it.
By their numbers in this assay, from the lowest: compound 3; then compound 1; then compound 2.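

In this assay, swapping the (2,3-dihydroxypropyl)carbamoyl group for hydroxymethyl gives a 21-fold lower number from compound 2 to compound 3 (1.32 log units; beyond the scatter), far more than the earlier step suggested. The 2-hydroxyethyl chain also outdoes the chain carrying piperidin-1-yl, with a 3.0-fold lower number from compound 1 to compound 3 (0.48 log units; beyond the scatter), so this position needs no piperidin-1-yl group to reach the lowest number of the three. Nothing available explains these shifts.

Going by these compounds, it remains open whether the hydroxy group itself matters or only the size of the chain. A methoxy group or a carboxylic acid at the chain end, or a longer chain ending in hydroxy, would help separate the two.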